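Ring-nitrogen substituent and maximal electroshock inhibition

This account rests on a few compounds, and the source may have more. Where it says the series, first, only, none or still open, it means among the compounds named here.

Of the compounds shown here, two of the shared core have been measured in a functional assay on the whole organism (strain Swiss albino) for inhibition, with Mus musculus as the target, in the maximal electroshock model, with a stated time of 2 h, at a dose of 25 mg/kg by the intraperitoneal route; a higher number here means more inhibition at the dose given (going by the name of the read-out), a lower number less inhibition. Compound 1 `O=C1C(c2ccccc2Cl)CC(c2ccccc2Cl)C(=O)N1Cc1ccccc1` carries benzyl on the amide-type nitrogen in the ring and gives 58.2%. Among the measured compounds shown here, compound 2 `NN1C(=O)C(c2ccccc2Cl)CC(c2ccccc2Cl)C1=O` carries amino at that nitrogen and gives 73.3%; among the two numbers compound 2 stands highest, with compound 1 its only neighbour. For the measured compounds named here, the single measured step, a number 15.1 percentage points higher from compound 1 to compound 2 (beyond the scatter), is modest and beyond the scatter.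

Compound 3 `Cc1ccccc1N1C(=O)C(c2ccccc2Cl)CC(c2ccccc2Cl)C1=O` is the next member: 2-methylphenyl in place of amino on an amide-type nitrogen in a ring. Going by the values given here, only the step of a number 15.1 percentage points higher from compound 1 to compound 2 (beyond the scatter) bears on this change; it shows amino above benzyl by a modest margin, and putting an aromatic group back in place of amino is therefore expected to carry the number back toward that of compound 1, so a step of a number 16.3 percentage points lower from compound 2 to compound 3 (beyond the scatter) is expected. Whether 2-methylphenyl on the amide-type nitrogen behaves like benzyl cannot be read from the data. The range is set wide. Compound 3 is expected to give 57%, between 35% and 78%.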

Compound 3, a percentage reported as inhibition, in the whole organism at one dose (the size of the read-out at that dose, not a potency): 60.6%
Beside the measured number, compound 3's estimate is 3.6 percentage points below it, and the stated range covers the measured number.
By their numbers in this assay, from the lowest: compounds 1 and 3 (each within the scatter of the next); then compound 2.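

Working notes on the amide-type nitrogen: in this assay, 2-methylphenyl in place of amino gives a number 12.7 percentage points lower from compound 2 to compound 3 (beyond the scatter) and so takes away the margin that amino held over benzyl, while 2-methylphenyl in place of benzyl gives a number 2.4 percentage points higher from compound 1 to compound 3 (within the scatter), which leaves these two groups indistinguishable in this read-out. Among the three groups now compared at this position, amino alone stands apart, with its steps to both benzyl and 2-methylphenyl beyond the scatter, and no compound shown goes against this; the change from benzyl to 2-methylphenyl, both of which carry a six-membered aromatic ring of carbon only, produces no separable shift. Nothing available bears on the reason for this difference.

Still open, from the compounds shown here alone, is whether the number of compound 2 is tied to amino itself or is shared by other small groups on this nitrogen, such as methyl, hydroxyl or dimethylamino. Also open, going by these compounds, is whether plain phenyl, or a longer chain such as 2-phenylethyl, would stay with compound 1 and compound 3 or move away from them.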